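A few compounds are considered here, and "the series" means these few. Any claim that something is new, unique, unknown or untested is made for them only; others in the source may bear on it.

Two compounds of the series have numbers in a functional assay on blood for inhibition of Polyunsaturated fatty acid 5-lipoxygenase (Homo sapiens); on this read-out higher numbers stand for weaker inhibition and lower numbers for stronger inhibition. Compound 1 `CN1C(=O)CCc2ccc(Sc3ncc([C@@]4(C)COC(C)(C)O4)s3)cc21` gives 60 nM. Compound 2 `C/C(=N\O)c1ccc(S(=O)(=O)c2ncc([C@@]3(C)COC(C)(C)O3)s2)cc1` gives 200 nM; this is the higher of the two numbers, and the gap to compound 1 lies beyond the scatter. Compound 3 `C/C(=N\OCC#N)c1ccc(S(=O)(=O)c2ncc([C@@]3(C)COC(C)(C)O3)s2)cc1` is not yet measured. It differs from compound 2 in one place: cyanomethyl in place of hydrogen on an oxygen, on the oxygen bound to the double-bonded nitrogen, so that hydroxy becomes cyanomethoxy. Among the compounds with values here, no step between measured compounds shows what such a change does; the two measured values concern a different part of the structure and give no guidance here. With nothing to argue otherwise, the step is expected to stay within the scatter, with no clear direction, as no change at the digits printed from compound 2 to compound 3 (within the scatter). Compound 3 is therefore estimated at 200 nM in this assay, with a range from 70 nM to 600 nM to allow for a wider movement either way.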

Compound 3, half-maximal inhibitory concentration: 120 nM
Estimate against measurement, compound 3: 1.7-fold (0.22 log units) above; low and high end bracket the measured number.
By their numbers in this assay, from the lowest: compounds 1, 3 and 2 (each within the scatter of the next, the first and the last beyond it).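

In this assay there is a 1.7-fold lower number from compound 2 to compound 3 (0.22 log units; within the scatter) on placing cyanomethyl on the oxygen bound to the double-bonded nitrogen. The hydroxy hydrogen is therefore not required to hold the number at this level, and this oxygen accepts a substituent without a move beyond the scatter. Nothing at hand bears on what lies behind this step.

From the compounds shown here alone, whether the nitrile of the cyanomethyl counts for anything stays open: methyl, a longer plain chain, or a chain ending in an amine or a carboxylic acid on the same oxygen would separate the nitrile from the simple loss of the hydrogen. Compound 1 differs from compound 2 and compound 3 in more than one place, so whether cyanomethoxy behaves the same way on other parts of the series also remains unsettled.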